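Compound 3 to compound 4: hydrogen for hydroxy

The source may hold more compounds than are shown below. What is called first, only, known or untested is meant among the compounds shown, and "the series" means these compounds.

In a physicochemical assay for lipophilicity (on this read-out higher numbers stand for higher lipophilicity and lower numbers for lower lipophilicity), compound 1 `CC(C)(O)C(=O)Nc1ccc(Cl)cc1` gives 2 and compound 2 `CC(C)(O)C(=O)Nc1ccc([N+](=O)[O-])cc1` gives 1.61. Compound 3 `CC(O)(C(=O)Nc1ccc([N+](=O)[O-])c(C(F)(F)F)c1)C(F)(F)F` has the highest number of the three, 3.21. Compound 4 `CC(C(=O)Nc1ccc([N+](=O)[O-])c(C(F)(F)F)c1)C(F)(F)F` is unmeasured. The change is hydrogen in place of hydroxy on a saturated chain carbon bound to a carbonyl carbon and two saturated chain carbons, with hydrogen in place of hydroxy on a saturated chain carbon bound to a carbonyl carbon and two saturated chain carbons. Among the measured compounds shown here, no measured step makes this replacement. For the measured compounds named here, the only measured step, a number 0.39 log units lower from compound 1 to compound 2 (beyond the scatter), lies on an aromatic carbon and gives no more than a rough scale. A modest rise is expected, with the estimated step of a number 0.29 log units higher from compound 3 to compound 4 (within the scatter). For compound 4 the estimate is 3.5, with an expected range from 3 to 4.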

Compound 4, partition coefficient: 3.71
For compound 4 the middle estimate is 0.21 log units below the measured one; measured number inside the range.
By their numbers in this assay, from the lowest: compound 2; then compound 1; then compound 3; then compound 4.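

At the saturated chain carbon bound to a carbonyl carbon and two saturated chain carbons, hydrogen in place of hydroxy gives, in this assay, a number 0.50 log units higher from compound 3 to compound 4 (beyond the scatter). Among the compounds shown here, this is the first measured step at this place; the only earlier one, a number 0.39 log units lower from compound 1 to compound 2 (beyond the scatter), lies on an aromatic carbon and is a different replacement. Nothing available explains the size of the new step.

Open, as far as these compounds go, is whether hydrogen in place of hydroxy gives a step of similar size in compound 1 or compound 2. Also open, from the compounds shown here alone, is where a methoxy or an amine at this carbon would fall on this read-out.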